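A few compounds are considered here, and "the series" means these few. Any claim that something is new, unique, unknown or untested is made for them only; others in the source may bear on it.

Compounds measured so far and their numbers:
compound 1 `CCOC(=O)c1sc(-c2ccccn2)nc1N1CCC(NCc2ccc(C(F)(F)F)cc2)CC1`, 14.6%; compound 2 `CCOC(=O)c1sc(-c2ccncc2)nc1N1CCC(NCc2ccccc2)CC1`, 10.8%; compound 3 `CCOC(=O)c1sc(-c2ccncc2)nc1N1CCC(NCc2ccc(OC)cc2)CC1`, 16.1%.

These three share one core and differ only in the group on the benzyl ring and in which pyridine is attached. In an ADME assay on RAW264.7 cells (Mus musculus) for cytotoxicity, read by MTT assay, with a stated time of 72 h, tested at 50 uM (on this read-out higher numbers stand for more inhibition at the one concentration tested (going by the name of the read-out) and lower numbers for less inhibition), compound 3 gives 16.1%. This is the largest of the three numbers, but compound 1 with 14.6% and compound 2 with 10.8% both lie within the usual scatter of it, so the three are not separated.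

Compound 4 `CCOC(=O)c1sc(-c2ccncc2)nc1N1CCC(NCc2ccc(C(F)(F)F)cc2)CC1` keeps everything of compound 3 except one group: trifluoromethyl in place of methoxy on an aromatic carbon. Among the measured compounds shown here, only one measured step touches this position, a number 5.3 percentage points higher from compound 2 to compound 3 (within the scatter), and it stayed within the scatter. Compound 1 carries the trifluoromethyl group on a different pyridine and gives 14.6%, also within the scatter of compound 3. Nothing seen so far suggests a change beyond the scatter, so compound 4 is expected to show a number 2.1 percentage points lower from compound 3 to compound 4 (within the scatter). The estimate for compound 4 in this assay is 14%, with a range from 5% to 25%.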

Compound 4, a percentage reported as inhibition, at one concentration (the size of the read-out at that concentration, not a potency): 18.1%
The estimate for compound 4 lay 4.1 percentage points below the measured number, within the range that was stated.
By their numbers in this assay, from the lowest: compounds 2, 1, 3 and 4 (each within the scatter of the next).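

With a number 2 percentage points higher from compound 3 to compound 4 (within the scatter) and a number 7.3 percentage points higher from compound 2 to compound 4 (within the scatter) in this assay, hydrogen, methoxy and trifluoromethyl can now be compared at this place on the benzyl ring, and no exchange among them leaves the scatter. The pyridine also gets its first comparison in which nothing else differs: a number 3.5 percentage points higher from compound 1 to compound 4 (within the scatter) shows that pyridin-4-yl in place of pyridin-2-yl likewise stays within the scatter. Nothing available here gives a reason for these small differences.

Still open, on these data alone, is whether an amine or a carboxylic acid on this ring would give a step beyond the scatter. With a single concentration tested, these numbers also leave open how the compounds would behave at other concentrations.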